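Aryl variation on the thioether side chain

The source may report more compounds than this note shows. Statements on the series, on what has been measured and on what is new or still open speak of the compounds shown alone.

Measured so far:
compound 1 `CC(Sc1nc2nn(C3COC3)cc2c(=O)n1-c1ccccc1)c1ccccn1` — 480 nM
compound 2 `CC(Sc1nc2nn(C3COC3)cc2c(=O)n1-c1ccccc1)c1cccnc1` — 250 nM

In an assay on isolated protein for inhibition of Retinaldehyde dehydrogenase 3 (Homo sapiens) (on this read-out higher numbers stand for weaker inhibition and lower numbers for stronger inhibition), compound 1 gives 480 nM and compound 2 gives 250 nM. Compound 2 carries the lowest of the two numbers; its nearest neighbour is compound 1, and the step of a 1.9-fold lower number from compound 1 to compound 2 (0.28 log units; within the scatter) stays within the scatter, so the pair cannot be ordered on these data.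

Compound 3 `CC(Sc1nc2nn(C3COC3)cc2c(=O)n1-c1ccccc1)c1ccccc1` has not yet been measured. It differs from compound 2 by phenyl in place of pyridin-3-yl on a saturated chain carbon bound to a saturated chain carbon and a sulfur. Within the data shown here, the only measured step, a 1.9-fold lower number from compound 1 to compound 2 (0.28 log units; within the scatter), exchanges pyridin-2-yl for pyridin-3-yl at the same place and bears on the present change only loosely; no measured pair sets a pyridinyl against a phenyl. On that basis no step beyond the scatter is expected, a 1.6-fold higher number from compound 2 to compound 3 (0.20 log units; within the scatter). Compound 3 is therefore estimated at 400 nM, with a range from 150 nM to 1200 nM.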

Compound 3, half-maximal inhibitory concentration: 109 nM
The estimate for compound 3 lay 3.7-fold (0.56 log units) above the measured number; the measured number lies below the stated range.
By their numbers in this assay, from the lowest: compound 3; then compounds 2 and 1 (each within the scatter of the next).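

At the aryl group on the saturated chain carbon bound to a saturated chain carbon and a sulfur, phenyl separates from both pyridinyl groups in this assay with a 2.3-fold lower number from compound 2 to compound 3 (0.36 log units; beyond the scatter) and with a 4.4-fold lower number from compound 1 to compound 3 (0.64 log units; beyond the scatter) as modest steps beyond the scatter. The earlier comparison, pyridin-3-yl in place of pyridin-2-yl, showed only a 1.9-fold lower number from compound 1 to compound 2 (0.28 log units; within the scatter) and left the position without a readable preference. This position therefore does respond to the aryl group, and among these three compounds the carbon-only ring gives the lowest number, although no supporting measurement accounts for this.

As far as these compounds go, it remains open how a fluoro or methoxy group on the phenyl would read. From the compounds shown here alone, a larger aryl group such as naphthyl also remains untested against compound 3 in these data.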